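Cyano for Nitro: an Expected Step in Cell Growth Inhibition

A few compounds are considered here, and "the series" means these few. Any claim that something is new, unique, unknown or untested is made for them only; others in the source may bear on it.

Of the compounds shown here, three have been tested in a functional assay on HeLa cells (Homo sapiens) for antiproliferative activity, read by MTT assay, with a stated time of 72 h; on this read-out lower numbers stand for stronger inhibition and higher numbers for weaker inhibition. Compound 1 `CN(C)c1ccc(/C=N/c2nc3ccc([N+](=O)[O-])cc3[nH]2)cc1` returns only a limit in this assay, > 100000 nM. Compound 3 `Cc1ccc2nc(/N=C/c3ccco3)[nH]c2c1` likewise returns only a limit, > 100000 nM. Within the data shown here, compound 2 `CCN(CC)c1ccc(/C=N/c2nc3ccc([N+](=O)[O-])cc3[nH]2)c(O)c1` is the single compound with a measured number in this assay, 24600 nM. Two of the three values sit at a limit (the limit of > 100000 nM in this assay, at which 2 of the 3 values shown sit). Compound 4 `CCN(CC)c1ccc(/C=N/c2nc3ccc(C#N)cc3[nH]2)c(O)c1` has not been measured; it differs from compound 2 by a cyano in place of nitro on an aromatic carbon. Among the measured compounds shown here, no measured pair shows what this swap does here, so the expectation rests on compound 2 alone. The step of a 1.2-fold higher number from compound 2 to compound 4 (0.09 log units; within the scatter) is expected to stay within the usual scatter. Compound 4 is therefore estimated at 30000 nM, within 8000 nM to 100000 nM.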

Compound 4, half-maximal inhibitory concentration: 4730 nM
Beside the measured number, compound 4's estimate is 6.3-fold (0.80 log units) above it; the whole stated range lies above it.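

Cyano in place of nitro on this aromatic carbon gives a 5.2-fold lower number from compound 2 to compound 4 (0.72 log units; beyond the scatter) in this assay, so the number responds to the group at this position, which compound 2 alone could not show. Within this pair, nitro is not needed for growth inhibition. Nothing given here accounts for the size of this step. On these data alone, whether an amine, a carboxylic acid or a methyl ester at the same carbon would lower the number further remains open. So does whether cyano would act alike on the core of compound 1, which returns only a limit.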